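The source may hold more compounds than are shown below. What is called first, only, known or untested is meant among the compounds shown, and "the series" means these compounds.

Compound 1: `CO[C@@H](C(=O)N[C@@H]1CC[C@H](O)CNC1=O)[C@H](O)[C@@H](O)[C@H](O)/C=C/C(C)(C)C` — > 150000 nM in a functional assay on HeLa cells (Homo sapiens) for cytotoxicity, read by colorimetric assay and neutral red uptake, with a stated time of 72 h; a higher number here means a weaker inhibitor, a lower number a stronger inhibitor
Compound 2: `CO[C@@H](C(=O)N[C@@H]1CCCCNC1=O)[C@H](O)[C@@H](O)[C@H](O)/C=C/C(C)(C)C` — 2100 nM
Compound 3: `CO[C@@H](C(=O)N[C@H]1CCCCNC1=O)[C@@H]1OC(C)(C)O[C@H](/C=C/C(C)(C)C)[C@@H]1O` — > 150000 nM

In this assay compound 3 gives only a limit, > 150000 nM, and so does compound 1, as the limit of > 150000 nM in this assay, at which 2 of the 3 values shown sit, shows. Within the data shown here, compound 2 stands at a real number; the one measured step, an at least 71-fold lower number from compound 1 to compound 2 (1.85 log units; beyond the scatter), is large but concerns a hydroxy group, not configuration. Compound 4, `CO[C@@H](C(=O)N[C@@H]1CCCCNC1=O)[C@@H]1OC(C)(C)O[C@H](/C=C/C(C)(C)C)[C@@H]1O`, is the unmeasured partner: the two compounds have the same atoms and bonds and differ only in configuration as drawn: 1 of 6 stereo elements differ; a stereocentre at a saturated ring carbon is drawn S in compound 3 and R in compound 4. Among the measured compounds shown here, no measured step speaks to a change of configuration alone, so the expectation must lean on compound 2, which shares the drawn configuration at that ring carbon. Compound 4 is therefore expected to move inside the range, with the step of an at least 7.5-fold lower number from compound 3 to compound 4 (0.87 log units; beyond the scatter) estimated, giving an estimate of 20000 nM, between 2000 nM and 150000 nM.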

Compound 4, half-maximal inhibitory concentration: > 150000 nM
Compound 4 gave a limit, no number; the forecaster's own chance of this, stated with the estimate: 30%; at least 7.5-fold (0.87 log units) between middle value and limit.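

Compound 3 and compound 4 both give a limit rather than a number, so no step between them can be read: the limit of > 150000 nM in this assay, at which 3 of the 4 values shown sit.

On these data alone, whether the configuration at that saturated ring carbon affects the result in this assay stays open.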